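Dimethyltriazene in place of methyl-thienyl triazene on benzamide

The source may hold more compounds than are shown below. What is called first, only, known or untested is meant among the compounds shown, and "the series" means these compounds.

Compound 1 `CN(/N=N/c1ccc(C(N)=O)cc1)c1cccs1`: 2.9
Compound 2 `COC(=O)c1n[nH]c(C(C)C)c1/N=N/N(C)C`: 3.3
Compound 3 `Cc1nc(/N=N/N(C)C)c(C(N)=O)[nH]1`: 3.06

The three measured compounds were examined in a functional assay on L1210 cells (Mus musculus) for antiproliferative activity; a lower number here means a less potent compound, a higher number a more potent compound, by a factor of ten per unit of this negative logarithm. Compound 1 has the lowest of the three numbers: compound 3 lies within the scatter of it, whereas compound 2 lies beyond the scatter and above it. Compound 4 `CN(C)/N=N/c1ccc(C(N)=O)cc1` is not yet measured. It differs from compound 1 in one place: methyl in place of thiophen-2-yl on an amine nitrogen. For the measured compounds named here, no pair of measured compounds differs in just this way, so the size of the step has to be judged from the set as a whole. Compound 2 and compound 3 both carry the methyl-bearing triazene that compound 4 would carry, and both sit at or above compound 1, which suggests a small upward step or none beyond the scatter. Compound 4 is therefore estimated at 3.2, with a range from 2.7 to 3.7. This estimate means an expected step of a number 0.30 log units higher from compound 1 to compound 4 (within the scatter), modest and not far beyond the scatter.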

Compound 4, logarithm of the reciprocal of the active concentration, log(1/C): 3.51
Estimate against measurement, compound 4: 0.31 log units below; measured number inside the range.
By their numbers in this assay, from the lowest: compounds 1, 3, 2 and 4 (each within the scatter of the next, the first and the last beyond it).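

In this assay, methyl in place of thiophen-2-yl on an amine nitrogen gives a number 0.61 log units higher from compound 1 to compound 4 (beyond the scatter). For the compounds shown here, this is the first direct reading of this position, as the earlier compounds offered no pair that differed here alone. On this core, the five-membered aromatic ring can therefore be exchanged for a single carbon with no loss in this read-out, and with a gain beyond the usual scatter, although this rests on one pair. The data available offer no measured property that would explain the change.

As far as these compounds go, it remains open whether an ethyl group, a longer chain or a phenyl ring on this nitrogen would fall nearer to methyl or to thiophen-2-yl. From the compounds shown here alone, it is equally open whether thiophen-2-yl would have the same effect on the cores of compound 2 and compound 3.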